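Adding a Methyl When Every Reading Is a Limit

The compounds below may be only part of what the source reports. "The series", "measured", "known", "first", "only" and "open" are said of these compounds alone.

Of the compounds shown here, three sharing one core have been tested in an ADME assay on CHO cells (Cricetulus griseus) for inhibition, read by MTT assay (on this read-out lower numbers stand for stronger inhibition and higher numbers for weaker inhibition), and none has yet given an exact number. Compound 2 `CCN(CC)Cc1cccc(Nc2nc3ccccc3n2Cc2ccc(C(F)(F)F)cc2)c1O` stands at > 50000 nM, which is a limit of the assay. Compound 1 `CCN(CC)Cc1cccc(Nc2nc3ccccc3n2Cc2ccc(C#N)cc2)c1O` gives > 50000 nM, also a limit. Compound 3 `CCN(CC)Cc1c(Cl)ccc(Nc2nc3ccccc3n2Cc2ccc(C(F)(F)F)cc2)c1O` gives > 50000 nM, again a limit. The whole set is summed up by the limit of > 50000 nM in this assay, at which 3 of the 3 values shown sit.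

Compound 4 `CCN(CC)Cc1ccc(C)c(Nc2nc3ccccc3n2Cc2ccc(C(F)(F)F)cc2)c1O` changes compound 2 in one place, where methyl replaces hydrogen on an aromatic carbon, para to a (diethylamino)methyl group: methyl in place of hydrogen on an aromatic carbon.

The closest measured change is also a swap of hydrogen on an aromatic carbon, this time for chloro: a step that the two limits leave unreadable from compound 2 to compound 3. The swap of cyano for trifluoromethyl bears on it less directly: a step that the two limits leave unreadable from compound 1 to compound 2. Neither step has a readable size, so neither offers a measured size or direction to carry over. Among the compounds with values here, the only guide is that all three tested compounds share the same limit, so no change beyond the usual scatter is expected in this assay. The expected change is a number no higher from compound 2 to compound 4 (the limit leaves the size open). Compound 4 will most likely be reported as a limit too. For compound 4 the estimate is 50000 nM, with an expected range from 25000 nM to 100000 nM.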

Compound 4, half-maximal inhibitory concentration: 33900 nM
Estimate against measurement, compound 4: 1.5-fold (0.17 log units) above; measured number inside the range.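

Within the data shown here, compound 4 is the first in the set to give an exact number rather than a limit, which makes this carbon, ortho to a large group and para to a (diethylamino)methyl group, the first place where a change has a reading on at least one side. In this assay, among these compounds, methyl in place of hydrogen here gives an at least 1.4-fold lower number from compound 2 to compound 4 (0.16 log units; that floor lies within the scatter), so the true gap may be larger, but the floor alone does not establish a real change, and the earlier steps cannot be read at all. Most of the set still rests on a single limit: the limit of > 50000 nM in this assay, at which 3 of the 4 values shown sit.

The compounds shown leave open whether a longer chain such as ethyl, or a polar group such as an amine or a carboxylic acid, on this same carbon would bring the number clearly lower than methyl does. They also leave open whether methyl at this carbon would give a readable number with the nitrile of compound 1 in place of the trifluoromethyl group.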